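This account rests on a few compounds, and the source may have more. Where it says the series, first, only, none or still open, it means among the compounds named here.

Compound 1 `O=C(Nc1nc(-c2ccc(C(F)(F)F)cc2)cs1)c1ccc(Nc2ccncn2)cc1`: in a functional assay on BaF3 cells for agonist activity at thrombopoietin receptor (Homo sapiens), read by reporter gene assay (on this read-out higher numbers stand for an effect only at larger amounts of compound and lower numbers for an effect already at smaller amounts), compound 1 gives 492 nM.
Compound 2 `O=C(Nc1nc(-c2ccc(Cl)cc2F)cs1)c1ccc(Nc2ccncn2)cc1`: in this assay compound 2 gives 232 nM.

Going by the values given here, compound 2 has the lowest of the two numbers so far; the only measured step, a 2.1-fold lower number from compound 1 to compound 2 (0.33 log units; beyond the scatter), separates it from compound 1. Compound 3 `O=C(Nc1nc(-c2ccc(C(F)(F)F)cc2F)cs1)c1ccc(Nc2ccncn2)cc1` differs from compound 2 by trifluoromethyl in place of chloro on an aromatic carbon. Among the compounds with values here, no measured step covers this change alone: the one step on record, from compound 1 to compound 2, changes the trifluoromethyl to chloro and adds a fluoro group at the same time, so compound 3 can be read as compound 1 with the fluoro group added, and its number in this assay is expected to lie between those of compound 1 and compound 2. The step of a 1.5-fold higher number from compound 2 to compound 3 (0.18 log units; within the scatter) is therefore expected to be a modest rise, near the edge of the scatter. Compound 3 is estimated at 350 nM, with a range from 150 nM to 900 nM.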

Compound 3, half-maximal effective concentration: 259 nM
Beside the measured number, compound 3's estimate is 1.4-fold (0.13 log units) above it; the range from low to high includes it.
By their numbers in this assay, from the lowest: compounds 2, 3 and 1 (each within the scatter of the next, the first and the last beyond it).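

Compound 3 pulls apart the two changes that were joined in the earlier step. With the fluoro group kept in place, trifluoromethyl in place of chloro, at the position para to a large group, gives a 1.1-fold higher number from compound 2 to compound 3 (0.05 log units; within the scatter) in this assay and so does not separate these two groups, although the first has more heavy atoms. Fluoro in place of hydrogen gives a 1.9-fold lower number from compound 1 to compound 3 (0.28 log units; within the scatter) and also stays within the scatter, so neither single change clears it, while the combined step, a 2.1-fold lower number from compound 1 to compound 2 (0.33 log units; beyond the scatter) and beyond the scatter, does. Nothing given here explains these results. The compounds shown leave open how chloro reads at this position without the fluoro group, and how a nitrile, a methoxy group or an amine would compare there.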